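This account rests on a few compounds, and the source may have more. Where it says the series, first, only, none or still open, it means among the compounds named here.

In a functional assay on MCF7 cells (Homo sapiens) for cytotoxicity, read by fluorescence, with a stated time of 72 h (on this read-out higher numbers stand for weaker inhibition and lower numbers for stronger inhibition), compound 1 `CC(C)c1n[nH]c2c(NCc3ccc(-c4ccccn4)cc3)nc(S(C)(=O)=O)nc12` gives 460 nM, while compound 2 `CC(C)c1n[nH]c2c(NCc3ccc(-c4ccccn4)cc3)nc(NCC(C)(C)O)nc12` gives 24 nM. Compound 2 therefore holds the lower of the two numbers, and the gap between them lies beyond the usual scatter. The next compound to be tested, compound 3 `CC(C)c1n[nH]c2c(NCc3ccc(-c4ccccn4)cc3)nc(N[C@@H]3CCCC[C@H]3N)nc12`, keeps the core of compound 2 and changes only the group on the nitrogen: 2-aminocyclohexyl in place of 2-hydroxy-2-methylpropyl on a nitrogen on an aromatic ring. In words, 2-aminocyclohexyl stands in place of 2-hydroxy-2-methylpropyl, so the (2-hydroxy-2-methylpropyl)amino group becomes (2-aminocyclohexyl)amino.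

Among the measured compounds shown here, only one measured step bears on this change, and only indirectly. The large step of a 19-fold lower number from compound 1 to compound 2 (1.28 log units; beyond the scatter) came from replacing methylsulfonyl with (2-hydroxy-2-methylpropyl)amino on an aromatic carbon. It shows that the group at this place can move the number in this assay, but it compares no two amino groups. Compound 3 retains the amino link that compound 2 has, so no step beyond the scatter is expected. The estimated change is a 1.6-fold lower number from compound 2 to compound 3 (0.20 log units; within the scatter). For compound 3, the expected value is 15 nM, within an estimated range from 4 nM to 60 nM.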

Compound 3, half-maximal inhibitory concentration: 295 nM
Beside the measured number, compound 3's estimate is 20-fold (1.29 log units) below it; measured number outside the range, above it.
By their numbers in this assay, from the lowest: compound 2; then compounds 3 and 1 (each within the scatter of the next).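

In this assay, the step of a 12-fold higher number from compound 2 to compound 3 (1.09 log units; beyond the scatter) shows that the group on this nitrogen counts in its own right: the nitrogen on the aromatic ring stays in place, yet 2-aminocyclohexyl in place of 2-hydroxy-2-methylpropyl gives a large change, something the earlier pair, which compared an amino group only with methylsulfonyl, could not show. The large step seen earlier therefore does not carry over to every amino group at this place, since the step of a 1.6-fold lower number from compound 1 to compound 3 (0.19 log units; within the scatter) leaves (2-aminocyclohexyl)amino and methylsulfonyl within the scatter of each other. Nothing measured here explains why the two amino groups part so widely.

Among the compounds shown here, the single step changes the ring, the nitrogen in place of oxygen and the two defined stereocentres together, so what the shift follows remains open. A 2-hydroxycyclohexyl group, an open-chain 2-amino-2-methylpropyl group or the other stereoisomers of 2-aminocyclohexyl on the same nitrogen would be needed to pull these features apart.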